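From 3,4-dimethoxyphenyl to 2,3-dimethoxyphenyl in the series

A few compounds are considered here, and "the series" means these few. Any claim that something is new, unique, unknown or untested is made for them only; others in the source may bear on it.

In a functional assay on MGC-803 cells (Homo sapiens) for cytotoxicity, read by MTT assay, with a stated time of 72 h (on this read-out lower numbers stand for stronger inhibition and higher numbers for weaker inhibition), compound 1 `O=C1C(=Cc2ccc(F)cc2)C(=O)N(c2ccc(Cl)cc2)N1c1ccc(Cl)cc1` gives 26000 nM as a measured number. Compound 2 `COc1ccc(C=C2C(=O)N(c3ccc(Cl)cc3)N(c3ccc(Cl)cc3)C2=O)cc1OC` gives only a limit, > 128000 nM, and no number. Going by the values given here, the one measured step is an at least 4.9-fold higher number from compound 1 to compound 2 (0.69 log units; beyond the scatter), on 3,4-dimethoxyphenyl replacing 4-fluorophenyl at the place that changes again here. Compound 3 `COc1cccc(C=C2C(=O)N(c3ccc(Cl)cc3)N(c3ccc(Cl)cc3)C2=O)c1OC` differs from compound 2 by 2,3-dimethoxyphenyl in place of 3,4-dimethoxyphenyl on a double-bonded chain carbon bound to a double-bonded ring carbon. Among the compounds with values here, the only dimethoxyphenyl example so far, compound 2 at > 128000 nM, is a limit, so compound 3 is expected to stay close to it in this assay, with no step beyond the scatter. The expected step is an at least 1.1-fold lower number from compound 2 to compound 3 (0.06 log units; that floor lies within the scatter). Compound 3 is estimated at 110000 nM, within a range of 40000 nM to 250000 nM.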

Compound 3, half-maximal inhibitory concentration: 29600 nM
For compound 3 the middle estimate is 3.7-fold (0.57 log units) above the measured one; measured number below the stated range.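

In this assay, 2,3-dimethoxyphenyl in place of 3,4-dimethoxyphenyl on a double-bonded chain carbon bound to a double-bonded ring carbon gives an at least 4.3-fold lower number from compound 2 to compound 3 (0.63 log units; beyond the scatter), so with the same atoms at this place, how the two methoxy groups are arranged on the phenyl ring matters. Against 4-fluorophenyl, 2,3-dimethoxyphenyl gives a 1.1-fold higher number from compound 1 to compound 3 (0.06 log units; within the scatter), so the loss seen earlier belongs to the 3,4-dimethoxyphenyl arrangement and not to dimethoxyphenyl as such. The size of that loss stays a floor, since compound 2 gives a limit and not a number: the limit of > 128000 nM in this assay, at which 1 of the 3 values shown sits.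

Still open, going by these compounds, is whether a phenyl with a single methoxy group matches either dimethoxyphenyl at this place. Also open, on these data alone, is whether an amine or a carboxylic acid on that phenyl ring moves the number beyond the scatter.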